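The source may report more compounds than this note shows. Statements on the series, on what has been measured and on what is new or still open speak of the compounds shown alone.

Measured so far in an ADME assay on MT4 cells (Homo sapiens) for cytotoxicity, read by MTT assay; on this read-out lower numbers stand for higher toxicity in this test and higher numbers for lower toxicity in this test:
compound 1, `Cc1ccccc1C(=O)N(C(=S)OCCN1C(=O)c2ccccc2C1=O)c1ccc(Cl)cc1`: 21000 nM
compound 2, `Cc1ccc(N(C(=O)c2ccccc2C)C(=S)OCCN2C(=O)c3ccccc3C2=O)cc1`: > 100000 nM, a limit of the test and not a number
compound 3, `O=C1c2ccccc2C(=O)N1CCOC(=S)N(C(=O)c1ccc(Cl)cc1Cl)c1ccc(Cl)cc1`: 18000 nM

Among the measured compounds shown here, compound 2 is the one member of the set without a number: it reaches only the limit (the limit of > 100000 nM in this assay, at which 1 of the 3 values shown sits), so its place among the three is known only as this ceiling. Compound 1 and compound 3 both carry numbers, and the step of a 1.2-fold lower number from compound 1 to compound 3 (0.07 log units; within the scatter), which exchanges the aryl group on the carbonyl carbon, stays within the scatter. The step of an at least 4.7-fold higher number from compound 1 to compound 2 (0.67 log units; beyond the scatter) shows that the group on the nitrogen, not the one on the carbonyl carbon, is where the three compounds part.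

Compound 4, `Cc1ccc(N(C(=O)c2ccc([N+](=O)[O-])cc2Cl)C(=S)OCCN2C(=O)c3ccccc3C2=O)cc1`, is not yet measured. It differs from compound 2 as follows: 2-chloro-4-nitrophenyl in place of 2-methylphenyl on a carbonyl carbon. For the measured compounds named here, the only measured step that bears on this change is a 1.2-fold lower number from compound 1 to compound 3 (0.07 log units; within the scatter), and it did not move the read-out beyond the scatter. No step beyond the scatter is therefore expected from compound 2 to compound 4, the expected step being a number no higher from compound 2 to compound 4 (the limit leaves the size open). Compound 2 sits at the limit. Compound 4 is expected at or near the same limit, estimated at 100000 nM with a range from 30000 nM to 300000 nM.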

Compound 4, half-maximal cytotoxic concentration: 17000 nM
Estimate against measurement, compound 4: 5.9-fold (0.77 log units) above; measured number below the stated range.
By their numbers in this assay, from the lowest: compounds 4, 3 and 1 (each within the scatter of the next). At a limit, above all of these: compound 2.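

The group on the carbonyl carbon is not silent in this series: in this assay, the exchange for 2-chloro-4-nitrophenyl gives an at least 5.8-fold lower number from compound 2 to compound 4 (0.76 log units; beyond the scatter), whereas the exchange for 2,4-dichlorophenyl gave a 1.2-fold lower number from compound 1 to compound 3 (0.07 log units; within the scatter). The high reading of compound 2 therefore depends on the 2-methylphenyl on the carbonyl carbon as well as on the group on the nitrogen, and the nitrogen group alone does not decide where a compound falls. Compound 2 holds a limit and not a number, so the size of the new step is only a minimum: the limit of > 100000 nM in this assay, at which 1 of the 4 values shown sits.

The two exchanges differ both in the entering group and in the group on the nitrogen, so the compounds shown cannot tell whether the nitro group, the chloro or the nitrogen group's context accounts for the different outcomes. Also open, going by these compounds, is how the read-out would respond with an amine or a carboxylic acid in place of the nitro group, or with a plain phenyl on the carbonyl carbon.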